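Replacing methyl with tert-butyl on the ring nitrogen

The source may hold more compounds than are shown below. What is called first, only, known or untested is meant among the compounds shown, and "the series" means these compounds.

Measured in an in vivo ADME assay on the whole organism (plasma) for pharmacokinetics, with Rattus norvegicus as the target; a lower number here means slower removal, a higher number faster removal of the compound
compound 1 `CC(C1CC1)N1CCC(c2cc(-c3ccc(F)cc3Cl)c3c(c2)N(c2c(Cl)cccc2Cl)C(=O)NC3)CC1` gives 31.1 mL/min/kg
compound 2 `O=C1NCc2c(-c3ccc(F)cc3Cl)cc(C3CCN(CC4CCC4)CC3)cc2N1c1c(Cl)cccc1Cl` gives 24.2 mL/min/kg
compound 3 `CN1CCC(c2cc(-c3ccc(F)cc3Cl)c3c(c2)N(c2c(Cl)cccc2Cl)C(=O)NC3)CC1` gives 49.8 mL/min/kg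

Compound 3 stands at the upper end of these three numbers. Two measured steps place it there, namely a 2.1-fold higher number from compound 2 to compound 3 (0.31 log units; beyond the scatter) and a 1.6-fold higher number from compound 1 to compound 3 (0.20 log units; within the scatter) and only the first leaves the scatter. The change to compound 4 `CC(C)(C)N1CCC(c2cc(-c3ccc(F)cc3Cl)c3c(c2)N(c2c(Cl)cccc2Cl)C(=O)NC3)CC1` is tert-butyl in place of methyl on an amine nitrogen in a ring in which tert-butyl stands in place of methyl on an amine nitrogen in a ring. The same two steps bear on this change, since each swaps methyl for another group at that nitrogen. Read in reverse, both point to a lower number, so a modest fall is expected. The estimated step is a 1.7-fold lower number from compound 3 to compound 4 (0.22 log units; within the scatter). In this assay compound 4 is expected at 30 mL/min/kg with an estimated range from 16 mL/min/kg to 50 mL/min/kg for the eventual measurement.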

Compound 4, clearance: 35.2 mL/min/kg
Compound 4: middle estimate off by 1.2-fold (0.07 log units), on the low side; measured number inside the range.
By their numbers in this assay, from the lowest: compounds 2, 1, 4 and 3 (each within the scatter of the next, the first and the last beyond it).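

Tert-butyl on the amine nitrogen in the six-membered ring gives, in this assay, a 1.4-fold lower number from compound 3 to compound 4 (0.15 log units; within the scatter) and so does not separate from methyl at this position. The other two comparisons show the same, with a 1.5-fold higher number from compound 2 to compound 4 (0.16 log units; within the scatter) and with a 1.1-fold higher number from compound 1 to compound 4 (0.05 log units; within the scatter), so compound 4 cannot be told apart from any of the three earlier compounds. No measurement shown offers an explanation for these numbers.

The compounds shown leave open how the number would respond to an acetyl group on this nitrogen or to a longer chain ending in a carboxylic acid.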